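One Drawn Double Bond Flipped in a Cytotoxic Series

This account rests on a few compounds, and the source may have more. Where it says the series, first, only, none or still open, it means among the compounds named here.

Of the compounds shown here, three built on the same core have been tested in a functional assay on K562 cells (Homo sapiens) for cytotoxicity, read by sulforhodamine B assay, with a stated time of 48 h; a higher number here means a weaker inhibitor, a lower number a stronger inhibitor. Compound 1 `CCN(CC)CCCn1c(=O)/c(=C/c2ccccc2O)s/c1=C1/C(=O)Nc2ccc(C)cc21` gives 14800 nM, compound 3 `CCN(CC)CCCn1c(=O)/c(=C/c2ccc(O)cc2)s/c1=C1\C(=O)Nc2ccc(Cl)cc21` gives 24600 nM, and compound 2 `CN(C)CCn1c(=O)/c(=C/c2ccc(O)cc2)s/c1=C1/C(=O)Nc2ccc(F)cc21` gives 1300 nM, the lowest of the three numbers; its nearest neighbour is compound 1 and its furthest is compound 3, and both gaps lie beyond the usual scatter.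

Within the data shown here, compound 4 `CN(C)CCn1c(=O)/c(=C/c2ccc(O)cc2)s/c1=C1\C(=O)Nc2ccc(F)cc21` has not been measured in this assay. the two compounds have the same atoms and bonds and differ only in configuration as drawn: 1 of 2 stereo elements differ; a double bond is drawn E in compound 2 and Z in compound 4 No pair of measured compounds isolates this change, so its effect here is unknown. The expectation for compound 4 is a modest step of a 1.9-fold higher number from compound 2 to compound 4 (0.28 log units; within the scatter) towards a weaker inhibitor, possibly no larger than the scatter. Compound 4 is therefore estimated at 2500 nM, within a range from 800 nM to 8000 nM.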

Compound 4, half-maximal inhibitory concentration: 1300 nM
The estimate for compound 4 lay 1.9-fold (0.28 log units) above the measured number; measured number inside the range.
By their numbers in this assay, from the lowest: compounds 2 and 4 (each within the scatter of the next); then compounds 1 and 3 (each within the scatter of the next).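

Among these compounds, this is the first comparison in the set that isolates a single change: the fact that compounds 2 and 4 differ only in the configuration as drawn. In this assay, reversing the way this one double bond is drawn gives no change at the digits printed from compound 2 to compound 4 (within the scatter), so for this pair the drawn configuration makes no measurable difference to the read-out. From the compounds shown here alone, whether that holds with other groups remains open, and compound 1 and compound 3 cannot settle it, as each differs from this pair in more than one place. Going by these compounds, what a morpholine in place of the dimethylamino group would do also remains open.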